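This account rests on a few compounds, and the source may have more. Where it says the series, first, only, none or still open, it means among the compounds named here.

In a functional assay on KB cells (Homo sapiens) for cytotoxicity (on this read-out lower numbers stand for an effect already at smaller amounts and higher numbers for an effect only at larger amounts of compound), compound 1 (`CCC1=C(OC)C(CC)(CC)C(=O)C(C(=O)/C=C/c2ccccc2)=C1O`) gives 2.8 ug/mL and compound 2 (`CCC1=C(OC)C(CC)(CC)C(=O)C(C(=O)/C=C/c2ccc(C)cc2)=C1O`) gives 3 ug/mL on this read-out. These two numbers lie within the usual scatter of each other, so compound 2 stands level with compound 1. Compound 3 (`CCC1=C(OC)C(CC)(CC)C(=O)C(C(=O)/C=C/c2ccc(CC)cc2)=C1O`) has not yet been measured. Its change from compound 2 is methyl in place of hydrogen on a saturated chain carbon bound to an aromatic carbon and amounts to methyl in place of hydrogen on a saturated chain carbon bound to an aromatic carbon, turning 4-methylphenyl to 4-ethylphenyl. For the measured compounds named here, the only measured step that bears on this, methyl in place of hydrogen on an aromatic carbon, gave a 1.1-fold higher number from compound 1 to compound 2 (0.03 log units; within the scatter) and lies at a different place, so it is only a loose guide. No step beyond the scatter is therefore expected in this assay here. The expected step is no change at the digits printed from compound 2 to compound 3 (within the scatter) on this estimate. For compound 3 the estimated value is 3 ug/mL with an expected range from 1.5 ug/mL to 6 ug/mL in this measurement.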

Compound 3, concentration for half-maximal effect: 3.6 ug/mL
The estimate for compound 3 lay 1.2-fold (0.08 log units) below the measured number, and the stated range covers the measured number.
By their numbers in this assay, from the lowest: compounds 1, 2 and 3 (each within the scatter of the next).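

In this assay, the change from 4-methylphenyl to 4-ethylphenyl, methyl in place of hydrogen on a saturated chain carbon bound to an aromatic carbon, gives a 1.2-fold higher number from compound 2 to compound 3 (0.08 log units; within the scatter), so a second carbon in this group brings no step beyond the scatter. Measured against the unsubstituted phenyl group, the 4-ethylphenyl group gives a 1.3-fold higher number from compound 1 to compound 3 (0.11 log units; within the scatter), which shows that the whole ethyl group also stays within the scatter. No measurement at hand offers an explanation for this result.

Going by these compounds, what a longer chain, a methoxy group or an amine would do at this place stays open. So does whether any group here can move the number in this assay beyond the scatter.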